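Amino to bromo: compound 1 to compound 4

The compounds below may be only part of what the source reports. "The series", "measured", "known", "first", "only" and "open" are said of these compounds alone.

Within the data shown here, in a functional assay on the whole organism with Mus musculus as the target (on this read-out lower numbers stand for an effect already at smaller amounts and higher numbers for an effect only at larger amounts of compound), compound 1 (`COc1cc2c(cc1OC)C(c1ccc(N)cc1)=NN=C(S)C2`) gives 3.3 umol/kg, the lowest of the three numbers so far. Compound 2 (`COc1cc2c(cc1OC)C(c1ccc(Br)cc1)=NNC(=O)C2`) gives 82.5 umol/kg and compound 3 (`COc1cc2c(cc1OC)C(c1ccc(Br)cc1)=NN(C)C(=S)C2`) gives 60.4 umol/kg, both higher than compound 1 beyond the scatter. Compound 4 (`COc1cc2c(cc1OC)C(c1ccc(Br)cc1)=NN=C(S)C2`) has bromo in place of amino on an aromatic carbon, para to a large group: bromo in place of amino on an aromatic carbon. Compound 2 at 82.5 umol/kg and compound 3 at 60.4 umol/kg also carry bromo, though each differs from compound 4 elsewhere. In this assay a rise beyond the scatter is therefore expected, an estimated step of a 12-fold higher number from compound 1 to compound 4 (1.08 log units; beyond the scatter). For compound 4 the estimate is 40 umol/kg, with an expected range of 15 umol/kg to 110 umol/kg.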

Compound 4, dose for half-maximal effect: 33.3 umol/kg
Beside the measured number, compound 4's estimate is 1.2-fold (0.08 log units) above it, within the range that was stated.
By their numbers in this assay, from the lowest: compound 1; then compounds 4, 3 and 2 (each within the scatter of the next, the first and the last beyond it).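

The step of a 10-fold higher number from compound 1 to compound 4 (1.00 log units; beyond the scatter) in this assay isolates the change from 4-aminophenyl to 4-bromophenyl, with the rest of the core unchanged, and it lies beyond the scatter. Among these compounds, earlier bromo compounds differed from compound 1 in more than one place, so this is the first single-place reading at this position. Nothing at hand explains the size of this step.

From the compounds shown here alone, whether the rise follows from losing amino or from gaining bromo remains open. Also open, going by these compounds, is how hydroxyl, methylamino or a carboxylic acid would read on the same aromatic carbon.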